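Chloro added to the trifluoromethyl-bearing ring of compound 3

A few compounds are considered here, and "the series" means these few. Any claim that something is new, unique, unknown or untested is made for them only; others in the source may bear on it.

Going by the values given here, compound 3 `Cc1cc(C(=O)O)nn1Cc1cc(Br)ccc1OCc1cccc(C(F)(F)F)c1` gives 309 nM in an assay on CHO-K1 cells for displacement of a labelled ligand from prostaglandin E2 receptor EP1 subtype (Homo sapiens) (on this read-out lower numbers stand for stronger inhibition and higher numbers for weaker inhibition), the highest number of the three compounds measured so far. Compound 1 `Cc1cc(C(=O)O)nn1Cc1cc(Br)ccc1OCc1ccccc1` gives 6.46 nM and compound 2 `Cc1cc(C(=O)O)nn1Cc1cc(Br)ccc1OCc1ccc(Cl)cc1` gives 8.71 nM; these two stand within the scatter of each other. From compound 1 the step to compound 3 was a 48-fold higher number from compound 1 to compound 3 (1.68 log units; beyond the scatter), through a trifluoromethyl group entering in place of an aromatic hydrogen. Compound 4 `Cc1cc(C(=O)O)nn1Cc1cc(Br)ccc1OCc1ccc(Cl)c(C(F)(F)F)c1` differs from compound 3 by chloro in place of hydrogen on an aromatic carbon. Among the compounds with values here, one measured step bears on this change: a 1.3-fold higher number from compound 1 to compound 2 (0.13 log units; within the scatter), also a chloro in place of hydrogen on the same six-membered aromatic ring, which stayed within the scatter. Within the data shown here, no measured pair shows a chloro entering a ring that already carries a trifluoromethyl group, so the expectation rests on that single step alone. The expected step is therefore a 1.1-fold higher number from compound 3 to compound 4 (0.05 log units; within the scatter), with no direction beyond the scatter. Compound 4 is estimated at 350 nM, with a range from 120 nM to 1000 nM.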

Compound 4, half-maximal inhibitory concentration: 575 nM
Beside the measured number, compound 4's estimate is 1.6-fold (0.22 log units) below it; low and high end bracket the measured number.
By their numbers in this assay, from the lowest: compounds 1 and 2 (each within the scatter of the next); then compounds 3 and 4 (each within the scatter of the next).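

Chloro ortho to a trifluoromethyl group stays within the scatter in this assay, with a 1.9-fold higher number from compound 3 to compound 4 (0.27 log units; within the scatter), and this step agrees with the one on the core of compound 1: the same change on two cores in this assay, a 1.3-fold higher number (0.13 log units; within the scatter) from compound 1 to compound 2 and a 1.9-fold higher number (0.27 log units; within the scatter) from compound 3 to compound 4, 1.4-fold (0.14 log units) apart, within the scatter of two such steps. The large step that comes with trifluoromethyl also persists with chloro present, with a 66-fold higher number from compound 2 to compound 4 (1.82 log units; beyond the scatter), and its size agrees with the step without chloro: the same change on two cores in this assay, a 48-fold higher number (1.68 log units; beyond the scatter) from compound 1 to compound 3 and a 66-fold higher number (1.82 log units; beyond the scatter) from compound 2 to compound 4, 1.4-fold (0.14 log units) apart, within the scatter of two such steps. Across these four compounds the two changes therefore read as independent, with trifluoromethyl accounting for the large steps and chloro for none.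

Whether the large steps belong to trifluoromethyl itself stays open, since no smaller group, such as methyl or methoxy, is shown at that ring carbon. Also open, going by these compounds, is whether an amine or a nitrile there would follow the same course.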